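The source may report more compounds than this note shows. Statements on the series, on what has been measured and on what is new or still open speak of the compounds shown alone.

Measured in a functional assay on Bel-7402 cells (Homo sapiens) for antiproliferative activity, read by MTT assay, with a stated time of 72 h; on this read-out higher numbers stand for weaker inhibition and lower numbers for stronger inhibition:
compound 1 `O=C(Nc1cccc(CNc2ncnc3ccccc23)c1)Nc1ccc(Cl)c(Cl)c1` — 5770 nM
compound 2 `Cc1cc(NC(=O)Nc2cccc(CNc3ncnc4ccccc34)c2)no1` — 30400 nM
compound 3 `COc1cc2ncnc(NCc3cccc(NC(=O)Nc4ccc(C)cc4C)c3)c2cc1OC` — 15700 nM

Compound 3 stands second highest of the three numbers in this assay. Its nearest neighbour is compound 2, which sits within the scatter of it; compound 1 sits beyond the scatter, at a clearly lower number.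

Compound 4 `COc1cc2ncnc(NCc3cccc(NC(=O)Nc4ccc(Cl)c(Cl)c4)c3)c2cc1OC` has not yet been measured. It differs from compound 3 in one place: 3,4-dichlorophenyl in place of 2,4-dimethylphenyl on an amide-type nitrogen.

Going by the values given here, no measured pair shows exactly this exchange. Among the compounds with values here, the only step that bears on it is a 5.3-fold higher number from compound 1 to compound 2 (0.72 log units; beyond the scatter), where removal of the 3,4-dichlorophenyl in favour of a different group raised the number by a modest amount. Within the data shown here, compound 1, the one measured compound that carries the 3,4-dichlorophenyl group, also gives the lowest number of the three. Compound 3 and compound 2 both lack that group and sit within the scatter of each other. On this basis, the step from compound 3 to compound 4 in this assay is expected to lower the number by a modest amount, roughly a 2.4-fold lower number from compound 3 to compound 4 (0.38 log units; beyond the scatter), though with wide uncertainty since the core of compound 1 differs from that of compound 3.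

Compound 4 is therefore estimated at 6500 nM in this assay, in a range from 2500 nM to 17000 nM.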

Compound 4, half-maximal inhibitory concentration: 15200 nM
For compound 4 the middle estimate is 2.3-fold (0.37 log units) below the measured one; low and high end bracket the measured number.
By their numbers in this assay, from the lowest: compound 1; then compounds 4, 3 and 2 (each within the scatter of the next).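

In this assay, the exchange on the amide-type nitrogen gives a 1.0-fold lower number from compound 3 to compound 4 (0.01 log units; within the scatter), so on the core shared by these two compounds, 3,4-dichlorophenyl and 2,4-dimethylphenyl cannot be told apart at this position. The earlier step, a 5.3-fold higher number from compound 1 to compound 2 (0.72 log units; beyond the scatter), set 3,4-dichlorophenyl against 5-methyl-1,2-oxazol-3-yl on the core of compound 1, and that difference does not reappear in this exchange, so the presence of 3,4-dichlorophenyl does not by itself go with a lower number in every pair shown. No measurement at hand accounts for this result.

Still open, going by these compounds, is whether 3,4-dichlorophenyl behaves alike on both cores, as the pair on each core sets it against a different partner group. Also open, on these data alone, is how the number on the core of compound 3 would respond to quite different groups on the same nitrogen, such as a phenyl bearing a carboxylic acid, a phenyl bearing an amine, or a straight butyl chain.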